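The source may report more compounds than this note shows. Statements on the series, on what has been measured and on what is new or still open speak of the compounds shown alone.

Compound 1, whose structure is `Cc1ccc2c(O)cc(-c3cccc(Cl)c3)nc2n1`, carries a methyl group on its core and a chlorophenyl ring as the attached aryl group. In a functional assay on HCT-116 cells (Homo sapiens) for antiproliferative activity (a lower number here means a stronger inhibitor of growth, a higher number a weaker inhibitor of growth), compound 1 gives 25.7 nM. Compound 2, with the structure `Cc1cc(C)c2c(O)cc(-c3cccc(Cl)c3)nc2n1`, differs from it in one place: methyl in place of hydrogen on an aromatic carbon. In this assay compound 2 gives 170 nM, and the step of a 6.6-fold higher number from compound 1 to compound 2 (0.82 log units; beyond the scatter) shows that this single added methyl weakens growth inhibition by an amount that is modest but clearly beyond the usual scatter.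

Compound 3, with the structure `Cc1ccc2c(O)cc(-c3ccc4ccccc4c3)nc2n1`, keeps the core of compound 1 but carries a naphthyl ring in place of the chlorophenyl ring. How the two cores differ is not broken down here. In this assay compound 3 gives 3980 nM, the highest number among the three measured compounds, far above the values of compound 1 and compound 2.

Compound 4, with the structure `Cc1cc(C)c2c(O)cc(-c3ccc4ccccc4c3)nc2n1`, is related to compound 3 exactly as compound 2 is to compound 1: methyl in place of hydrogen on an aromatic carbon. The surroundings of the changed carbon are the same in both pairs, so this is the same change made on a different aryl-bearing core. Because the step of a 6.6-fold higher number from compound 1 to compound 2 (0.82 log units; beyond the scatter) was a modest weakening, a step of similar size is expected here, a 5.5-fold higher number from compound 3 to compound 4 (0.74 log units; beyond the scatter), though the change has been seen only once, so the expectation is uncertain. Compound 4 is therefore estimated to give 22000 nM in this assay, plausibly between 7000 nM and 70000 nM.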

Compound 4, concentration for 50% growth inhibition: 12600 nM
Beside the measured number, compound 4's estimate is 1.7-fold (0.24 log units) above it, and the stated range covers the measured number.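

In this assay, the methyl in place of hydrogen on an aromatic carbon raises the number on the naphthyl-bearing core as well, with a step of a 3.2-fold higher number from compound 3 to compound 4 (0.50 log units; beyond the scatter), so growth inhibition weakens here as it did on the chlorophenyl-bearing core. Set side by side, the two steps go the same way and cannot be told apart in size: the same change on two cores in this assay, a 6.6-fold higher number (0.82 log units; beyond the scatter) from compound 1 to compound 2 and a 3.2-fold higher number (0.50 log units; beyond the scatter) from compound 3 to compound 4, 2.1-fold (0.32 log units) apart, within the scatter of two such steps

This suggests that, across these two pairs, the effect of the added methyl carried from one aryl group to the other in both direction and rough size, so the earlier step was a fair guide to the later one, but two pairs are a small sample and do not establish a rule for the whole series, nor do they explain why the methyl weakens growth inhibition.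

The compounds shown leave open how another group on the same carbon, such as an ethyl chain, a methoxy group or an amine, would compare with methyl. They also leave open whether the methyl step would keep its direction and size with an aryl group other than chlorophenyl or naphthyl.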